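The compounds below may be only part of what the source reports. "The series", "measured", "known", "first", "only" and "open" are said of these compounds alone.

Three compounds share one core, an aromatic amide carrying a hexafluoro alcohol, and differ only in the group attached to the carbonyl. Compound 1 `CCC(C)C(=O)Nc1c(C(O)(C(F)(F)F)C(F)(F)F)ccc2ccccc12` carries a sec-butyl there; in an assay on LtK cells with ATP-sensitive inward rectifier potassium channel 11 (Homo sapiens) as the target (on this read-out lower numbers stand for an effect already at smaller amounts and higher numbers for an effect only at larger amounts of compound), compound 1 gives 177000 nM. Compound 2 `O=C(Nc1c(C(O)(C(F)(F)F)C(F)(F)F)ccc2ccccc12)c1ccccc1` carries a phenyl instead, and in this assay compound 2 gives 44 nM, which is a 4000-fold lower number from compound 1 to compound 2 (3.60 log units; beyond the scatter). Compound 3 `O=C(Nc1c(C(O)(C(F)(F)F)C(F)(F)F)ccc2ccccc12)c1cccc(Br)c1` carries a 3-bromophenyl; in this assay compound 3 gives 80 nM, the second highest of the three numbers, with a 2200-fold lower number from compound 1 to compound 3 (3.34 log units; beyond the scatter) and a 1.8-fold higher number from compound 2 to compound 3 (0.26 log units; within the scatter).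

Compound 4 `O=C(Nc1c(C(O)(C(F)(F)F)C(F)(F)F)ccc2ccccc12)c1cccc([N+](=O)[O-])c1` is the next step from compound 3: nitro in place of bromo on an aromatic carbon. Within the data shown here, only one measured step bears on it, the one from compound 2 to compound 3, which exchanged a hydrogen for a bromo at the same place and stayed within the scatter. Among the measured compounds shown here, no measured pair shows what a nitro does at this place, so the expectation rests on that single neighbouring step alone. On that basis compound 4 is expected to show no change at the digits printed from compound 3 to compound 4 (within the scatter), that is, no step beyond the scatter in this assay. The estimate for compound 4 is therefore 80 nM, with a range from 25 nM to 250 nM.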

Compound 4, half-maximal effective concentration: 117 nM
The estimate for compound 4 lay 1.5-fold (0.17 log units) below the measured number; the range from low to high includes it.
By their numbers in this assay, from the lowest: compounds 2, 3 and 4 (each within the scatter of the next, the first and the last beyond it); then compound 1.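

Swapping bromo for nitro on this aromatic carbon, meta to a large group, brings in more heavy atoms and two hydrogen-bond acceptors, yet compound 3 and compound 4 cannot be told apart in this assay (a 1.5-fold higher number from compound 3 to compound 4 (0.17 log units; within the scatter)). Among these compounds, measured against the plain phenyl, however, the two groups read differently: bromo stays within the scatter (a 1.8-fold higher number from compound 2 to compound 3 (0.26 log units; within the scatter)), while nitro gives the first step at this place that lies beyond it, though only a modest one (a 2.7-fold higher number from compound 2 to compound 4 (0.42 log units; beyond the scatter)). That step is tiny beside the one that brings in the whole ring (a 1500-fold lower number from compound 1 to compound 4 (3.18 log units; beyond the scatter)), so in these compounds replacing sec-butyl with a substituted phenyl counts for far more than the choice between these two ring substituents, and nothing available explains either result.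

From the compounds shown here alone, whether an amine or a carboxylic acid on this same carbon would stay close to compound 2 or move further away remains open. So does the question of whether a cyclohexyl or a longer chain on the carbonyl could come near the phenyl compounds or whether the aromatic ring itself is required.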